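From Carboxy to Propoxycarbonyl: Expectation for Compound 4

This account rests on a few compounds, and the source may have more. Where it says the series, first, only, none or still open, it means among the compounds named here.

Three compounds have been measured in an assay on isolated protein for inhibition of Fatty-acid amide hydrolase 1 (Homo sapiens), read by fluorescence, with a stated time of 30 min; a lower number here means a stronger inhibitor, a higher number a weaker inhibitor:

compound 1, `CC(C)NC(=O)c1cc(-c2cccc(OC(=O)NC3CCCCC3)c2)n(-c2ccccc2)n1`, gives 232 nM in this assay
compound 2, `O=C(NC1CCCCC1)Oc1cccc(-c2cc(C(=O)NC3CCCCC3)nn2-c2ccccc2)c1`, gives 288 nM in this assay
compound 3, `O=C(NC1CCCCC1)Oc1cccc(-c2cc(C(=O)O)nn2-c2ccccc2)c1`, gives 2270 nM in this assay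

Compound 3 stands highest of the three numbers in this assay; its nearest neighbour is compound 2, with a 7.9-fold higher number from compound 2 to compound 3 (0.90 log units; beyond the scatter), and furthest is compound 1, with a 9.8-fold higher number from compound 1 to compound 3 (0.99 log units; beyond the scatter). Compounds 1 and 2 lie within the scatter of each other, shown by a 1.2-fold higher number from compound 1 to compound 2 (0.09 log units; within the scatter).

The unmeasured compound 4, `CCCOC(=O)c1cc(-c2cccc(OC(=O)NC3CCCCC3)c2)n(-c2ccccc2)n1`, differs from compound 3 in one place: propyl in place of hydrogen on an oxygen next to a carbonyl group. The two measured steps that bear on this change are those in which the hydroxy of compound 3 is replaced on the carbonyl carbon, namely the reverse of the steps from compound 1 and compound 2 to compound 3, each of which was a modest step beyond the scatter. Compound 4 does not carry an amide but a propyl on the oxygen, so the measured steps give only a rough guide; still, the expectation is that replacing the hydroxy moves the number downward, by a step of about a 3.2-fold lower number from compound 3 to compound 4 (0.51 log units; beyond the scatter). Compound 4 is therefore estimated at 700 nM, with a range of 200 nM to 2500 nM.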

Compound 4, half-maximal inhibitory concentration: 27 nM
Compound 4: the middle estimate sits 26-fold (1.41 log units) above what was measured; measured number below the stated range.
By their numbers in this assay, from the lowest: compound 4; then compounds 1 and 2 (each within the scatter of the next); then compound 3.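

Capping the carboxy of compound 3 as propoxycarbonyl turns out to be the largest change at this carbonyl carbon in this assay (an 84-fold lower number from compound 3 to compound 4 (1.92 log units; beyond the scatter)), larger than either of the steps from the two amides to the acid. The earlier compounds shown here showed only that isopropylamino and cyclohexylamino gave numbers within the scatter of each other, both well below the hydroxy, and could suggest that any such replacement lands in that same range. Propoxy does not: it goes clearly beyond both amides (an 11-fold lower number from compound 2 to compound 4 (1.03 log units; beyond the scatter); an 8.6-fold lower number from compound 1 to compound 4 (0.93 log units; beyond the scatter)), so what is attached through the carbonyl carbon still matters after the hydroxy has gone, and nothing available explains why this is so.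

The compounds shown leave open whether a shorter methoxy or a longer butoxy would hold this low number, and whether propylamino, carrying the same chain on an amide-type nitrogen, would match propoxy or stay with the other amides. Going by these compounds, all four compounds also share the same cyclohexyl group on the far carbamate, so whether the propoxy step would carry over with a phenyl or a longer chain there remains unknown.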